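Removing a methoxy group from an antiproliferative compound

A few compounds are considered here, and "the series" means these few. Any claim that something is new, unique, unknown or untested is made for them only; others in the source may bear on it.

In a functional assay on HeLa cells (Homo sapiens) for antiproliferative activity, read by MTT assay, with a stated time of 72 h (a higher number here means a weaker inhibitor, a lower number a stronger inhibitor), compound 1 (`COc1ccc(N2C(=O)COc3ccc(-c4cnc(Cl)c(NS(=O)(=O)c5ccc(F)cc5)c4)cc32)cc1`) gives 8320 nM and compound 2 (`COc1cccc(N2C(=O)COc3ccc(-c4cnc5ccccc5c4)cc32)c1`) gives 11400 nM as its measured value. These two numbers lie within the usual scatter of each other, so compound 2 cannot be told apart from compound 1 on this read-out. Compound 3 (`O=C1COc2ccc(-c3cccc(NS(=O)(=O)c4ccc(F)cc4)c3)cc2N1C1CC1`) reads > 40000 nM in this assay and that entry is a limit of the assay, not a number.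

Compound 4 (`O=C1COc2ccc(-c3cnc4ccccc4c3)cc2N1c1ccccc1`) has not yet been measured. It differs from compound 2 by a single change, hydrogen in place of methoxy on an aromatic carbon in all, which puts hydrogen in place of methoxy on an aromatic carbon, so that 3-methoxyphenyl becomes phenyl. No measured pair among these compounds shows this change, so the data give no direct guide to its size. The expectation therefore rests on compound 2 at 11400 nM as the starting point. Expected here is a 1.1-fold higher number from compound 2 to compound 4 (0.02 log units; within the scatter) in this assay and so no change beyond the scatter, in either direction. Compound 4 is estimated at 12000 nM with an expected range from 5000 nM to 30000 nM once it is tested.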

Compound 4, half-maximal inhibitory concentration: > 40000 nM
Compound 4 was reported as a limit (the forecaster's own chance of this, stated with the estimate: 15%); middle value at least 3.3-fold (0.52 log units) away from the limit.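

In this assay, among these compounds, the exchange of 3-methoxyphenyl for phenyl on the shared core produces an at least 3.5-fold higher number from compound 2 to compound 4 (0.54 log units; beyond the scatter) and so shows, for the first time, that this position is not indifferent to the change. Among the compounds shown here, the methoxy group is the only thing that separates compound 2, which has a measurable value, from compound 4, which has none, so this single group on the aromatic carbon matters for the read-out in this pair. The value of compound 4 is a limit of the assay and not a number, so the step has a minimum size but no known full size: the limit of > 40000 nM in this assay, at which 2 of the 4 values shown sit.

The compounds shown leave open whether a hydroxyl group, an amine or a longer ether chain such as ethoxy on the same aromatic carbon would keep the activity of compound 2 or lose it as phenyl does. From the compounds shown here alone, how the same exchange would read on compound 1, with its different substitution on the core, also stays open, as does how much weaker compound 4 really is.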